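The source may hold more compounds than are shown below. What is called first, only, known or untested is meant among the compounds shown, and "the series" means these compounds.

In a functional assay on MCF7 cells (Homo sapiens) for inhibition, read by fluorescence, with a stated time of 72 h (a higher number here means a weaker inhibitor, a lower number a stronger inhibitor), three compounds with a shared core have been measured. Compound 1 `CC(C)n1cnc2c(NC(=N)N)nc(NCCCCCCO)nc21` gives 5200 nM, compound 2 `CC[C@H](CO)Nc1nc(NC(=N)N)c2ncn(C(C)C)c2n1` gives 4500 nM, and compound 3 `CC[C@@H](CO)Nc1nc(NC(=N)N)c2ncn(C(C)C)c2n1` gives 1600 nM, the lowest number of the three and so the strongest inhibitor so far. Its lead is modest on both sides: a 2.8-fold lower number from compound 2 to compound 3 (0.45 log units; beyond the scatter), and a 3.3-fold lower number from compound 1 to compound 3 (0.51 log units; beyond the scatter).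

The next compound, compound 4 `CC(C)[C@@H](CO)Nc1nc(NC(=N)N)c2ncn(C(C)C)c2n1`, differs from compound 3 in a single place: methyl in place of hydrogen on a saturated chain carbon bound to two saturated chain carbons. Methyl replaces hydrogen on a saturated chain carbon bound to two saturated chain carbons, which turns ethyl into isopropyl.

Within the data shown here, no measured step adds this methyl, so the evidence is indirect. Among the measured compounds shown here, two steps bear on the same side chain. Replacing the whole 6-hydroxyhexyl with 1-(hydroxymethyl)propyl gave a 1.2-fold lower number from compound 1 to compound 2 (0.06 log units; within the scatter) in one configuration and a 3.3-fold lower number from compound 1 to compound 3 (0.51 log units; beyond the scatter) in the other. Changing only the configuration gave a 2.8-fold lower number from compound 2 to compound 3 (0.45 log units; beyond the scatter). These far larger edits to the chain moved the number only modestly, so a single added methyl should do no more than that, and its direction cannot be read from these data.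

The estimated change is small, a 1.1-fold higher number from compound 3 to compound 4 (0.05 log units; within the scatter), which would not stand out from the scatter in this assay. For compound 4 the expected value is 1800 nM, with an estimated range from 600 nM to 5000 nM.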

Compound 4, half-maximal inhibitory concentration: 2100 nM
The estimate for compound 4 lay 1.2-fold (0.07 log units) below the measured number; low and high end bracket the measured number.
By their numbers in this assay, from the lowest: compounds 3 and 4 (each within the scatter of the next); then compounds 2 and 1 (each within the scatter of the next).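

At the saturated chain carbon bound to two saturated chain carbons, the shift from ethyl to isopropyl gives a 1.3-fold higher number from compound 3 to compound 4 (0.12 log units; within the scatter) in this assay, so this carbon takes one extra methyl and compounds 3 and 4 cannot be told apart in this assay. Among these compounds, this is the first direct reading at this carbon: the earlier steps replaced the whole side chain or altered its configuration, whereas this one adds a single carbon and leaves everything else in place. The branched side chain also keeps a modest lead over the two other compounds, with a 2.1-fold lower number from compound 2 to compound 4 (0.33 log units; beyond the scatter) and a 2.5-fold lower number from compound 1 to compound 4 (0.39 log units; beyond the scatter), although compound 2 is drawn with the opposite arrangement at the carbon bearing the side chain, so that step may not reflect the methyl alone.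

As far as these compounds go, how much bulk this carbon accepts remains open, since a tert-butyl, a cyclohexyl or a phenyl group here could behave quite differently from isopropyl, and so could an amine or a carboxylic acid in place of the hydroxyl of the hydroxymethyl. The measurements shown also offer no explanation for why the methyl fits at this carbon.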